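The source may report more compounds than this note shows. Statements on the series, on what has been measured and on what is new or still open speak of the compounds shown alone.

In a functional assay on MCF7 cells (Homo sapiens) for antiproliferative activity, read by MTT assay, with a stated time of 48 h (a lower number here means a stronger inhibitor, a higher number a weaker inhibitor), compound 1 (`COc1ccc(C(=O)c2ccc3c(c2)C=CC(C)(C)O3)c(NC(=O)CN)c1`) gives 680 nM. Compound 2 (`C=C(c1ccc(OC)cc1NC(=O)CN)c1ccc(OC)c2c1OC(C)(C)C=C2`) gives 220 nM, the lower of the two numbers, and the gap between them lies beyond the scatter. Compound 3 (`C=C(c1ccc(OC)cc1NC(=O)CNCC)c1ccc(OC)c2c1OC(C)(C)C=C2`) differs from compound 2 in one place: ethyl in place of hydrogen on an amine nitrogen. Within the data shown here, no measured pair shows this change, so only a small rise in the number is expected, possibly none beyond the scatter. The estimated change is a 1.4-fold higher number from compound 2 to compound 3 (0.13 log units; within the scatter). For compound 3 the estimated value is 300 nM, with an expected range of 110 nM to 800 nM.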

Compound 3, half-maximal inhibitory concentration: 2100 nM
The estimate for compound 3 lay 7.0-fold (0.85 log units) below the measured number; measured number above the stated range.
By their numbers in this assay, from the lowest: compound 2; then compound 1; then compound 3.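

In this assay, among these compounds, ethyl in place of hydrogen on the amine nitrogen brings a 9.5-fold higher number from compound 2 to compound 3 (0.98 log units; beyond the scatter) and this is the first reading of this position. Within this pair, the amino end of compound 2 cannot be swapped for the ethylamino end of compound 3 without a clear weakening. Nothing shown bears on the reason for this step. Open, on these data alone, is how methyl or a longer chain such as propyl on the same nitrogen would read, and whether dimethylamino would follow ethylamino.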